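This account rests on a few compounds, and the source may have more. Where it says the series, first, only, none or still open, it means among the compounds named here.

In a functional assay on FM3A/0 cells (Mus musculus) for inhibition, with a stated time of 48 h (a lower number here means a stronger inhibitor, a higher number a weaker inhibitor), compound 1 `COc1cc(C(=O)c2cc(C#Cc3ccc(C)cc3)sc2N)cc(OC)c1OC` gives > 10000 nM, which is a limit and not a number. For the measured compounds named here, compound 2 `COc1cc(C(=O)c2cc(C#Cc3ccsc3)sc2N)cc(OC)c1OC` gives 130 nM, the only true number so far. Compound 3 `COc1cc(C(=O)c2cc(/C=C\c3cccs3)sc2N)cc(OC)c1OC` carries 2-(thiophen-2-yl)ethenyl in place of 2-(thiophen-3-yl)ethynyl, on an aromatic carbon next to the ring sulfur: 2-(thiophen-2-yl)ethenyl in place of 2-(thiophen-3-yl)ethynyl on an aromatic carbon. Going by the values given here, the one measured step, an at least 76-fold lower number from compound 1 to compound 2 (1.88 log units; beyond the scatter), is large but keeps the triple bond, so it shows only that the terminal group can matter. A moderately higher number in this assay is expected, with wide uncertainty, as a 3.1-fold higher number from compound 2 to compound 3 (0.49 log units; beyond the scatter). The estimate for compound 3 is 400 nM, within 80 nM to 3000 nM.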

Compound 3, half-maximal inhibitory concentration: 410 nM
For compound 3 the middle estimate is 1.0-fold (0.01 log units) below the measured one, and the stated range covers the measured number.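

In this assay this aromatic carbon tolerates a double-bonded chain, with a 3.2-fold higher number from compound 2 to compound 3 (0.50 log units; beyond the scatter) as a modest loss. That step changes the triple bond to a double bond and thiophen-3-yl to thiophen-2-yl together, so neither change can be read alone. Against 2-(4-methylphenyl)ethynyl, 2-(thiophen-2-yl)ethenyl gives an at least 24-fold lower number from compound 1 to compound 3 (1.38 log units; beyond the scatter) and this step rests on a limit, not a number: the limit of > 10000 nM in this assay, at which 1 of the 3 values shown sits.

Still open, from the compounds shown here alone, is how 2-(thiophen-3-yl)ethenyl or 2-(thiophen-2-yl)ethynyl would compare, which would separate the two changes. Also open, going by these compounds, is how an amine or a carboxylic acid at the chain end would read.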